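A new group on the sulfonyl sulfur

This account rests on a few compounds, and the source may have more. Where it says the series, first, only, none or still open, it means among the compounds named here.

In an ADME assay (liver) for metabolic stability, with Liver microsome (Homo sapiens) as the target, read by LC-MS, using microsomes and NADPH, with a stated time of 5 min, at 37 degrees C (a higher number here means faster removal of the compound, a lower number slower removal), compound 3 `CCn1c([C@@H](C)NS(=O)(=O)c2c(F)cc(F)cc2F)nc2ccc(C(F)(F)F)cc21` gives 19 mL.min-1.g-1 and stands level, within the scatter, with compound 1 `CCn1c([C@@H](C)NS(=O)(=O)c2ccc(F)cc2)nc2ccc(C(F)(F)F)cc21` at 26 mL.min-1.g-1 on the same scale. For compound 2 `CCn1c([C@@H](C)NS(=O)(=O)c2ccc(C)cc2)nc2ccc(C(F)(F)F)cc21` the result is only a limit of > 100 mL.min-1.g-1 and no number. Compound 4 `CCn1ncc(S(=O)(=O)N[C@H](C)c2nc3ccc(C(F)(F)F)cc3n2CC)c1C` brings one change (1-ethyl-5-methyl-1H-pyrazol-4-yl in place of 2,4,6-trifluorophenyl on a sulfonyl sulfur) and keeps the shared core. Going by the values given here, three measured steps bear on it. Added fluorines moved little (a 1.4-fold lower number from compound 1 to compound 3 (0.14 log units; within the scatter)) but methyl-bearing compound 2 stood clearly apart (an at least 3.8-fold higher number from compound 1 to compound 2 (0.58 log units; beyond the scatter) and an at least 5.2-fold lower number from compound 2 to compound 3 (0.72 log units; beyond the scatter)). The entering group also holds a methyl on a new ring, so a modest rise is expected. The expected step is a 2.1-fold higher number from compound 3 to compound 4 (0.32 log units; beyond the scatter) with real uncertainty. Compound 4 is estimated at 40 mL.min-1.g-1 within an expected range of 13 mL.min-1.g-1 to 95 mL.min-1.g-1 in this assay terms.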

Compound 4, intrinsic clearance in microsomes: > 100 mL.min-1.g-1
Compound 4: no number, only a limit (the forecaster's own chance of this, stated with the estimate: 15%); middle value at least 2.5-fold (0.39 log units) away from the limit.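

At this position on the sulfonyl sulfur, a five-membered aromatic ring with two hetero atoms also gives fast removal in this assay, with an at least 5.2-fold higher number from compound 3 to compound 4 (0.72 log units; beyond the scatter) and an at least 3.8-fold higher number from compound 1 to compound 4 (0.58 log units; beyond the scatter). The result for compound 4 is a limit and not a number, so these steps give only their smallest possible size. The step between compound 2 and compound 4 cannot be read, since both results are limits: the limit of > 100 mL.min-1.g-1 in this assay, at which 2 of the 4 values shown sit.

The compounds shown do not separate the effect of the new ring from that of its methyl and ethyl groups. As far as these compounds go, how a pyridyl ring or an unsubstituted pyrazole would behave on the sulfonyl sulfur stays open.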